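The compounds below may be only part of what the source reports. "The series", "measured", "known", "first", "only" and "open" are said of these compounds alone.

The measured compounds:
compound 1, `COc1cc(/C=C/c2nc(NCc3ccccc3)c3sccc3n2)cc(OC)c1OC`, which in an ADME assay on RAW264.7 cells (Mus musculus) for cytotoxicity, read by MTT assay (a lower number here means a stronger inhibitor, a higher number a weaker inhibitor), gives > 50000 nM;
compound 2, `COc1ccc(CNc2nc(/C=C/c3cc(OC)c(OC)c(OC)c3)nc3ccsc23)cc1`, which in this assay gives > 50000 nM.

Each of these values is a limit of the assay, not a number. Compound 2 therefore stands at the upper edge of what this assay reports, on (the limit of > 50000 nM in this assay, at which 2 of the 2 values shown sit), together with the other value shown. Going by the values given here, the only measured step, a step that the two limits leave unreadable from compound 1 to compound 2, runs between two such limits and cannot be read in size or direction.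

Compound 3, `COc1cc(/C=C/c2nc(NCc3ccc(Cl)cc3)c3sccc3n2)cc(OC)c1OC`, differs from compound 2 by a single change: chloro in place of methoxy on an aromatic carbon. Among the compounds with values here, the one measured step is the only evidence that bears on this change, and it gives no readable size, so no step beyond the scatter can be predicted in either direction. It is expected that compound 3 remains near the limit, with the step that the limit leaves unreadable from compound 2 to compound 3 estimated as no more than scatter. The value of compound 3 in this assay is estimated at 60000 nM, in the range 20000 nM to 200000 nM, with a limit again the most likely outcome.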

Compound 3, half-maximal inhibitory concentration: > 50000 nM
Compound 3 gave a limit, no number (the forecaster's own chance of this, stated with the estimate: 80%); the middle value is on the limit's open side.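

Compound 3 gives > 50000 nM in this assay, which is again a limit of the assay and not a number, so no step among compound 1, compound 2 and compound 3 can be read in size or direction: the limit of > 50000 nM in this assay, at which 3 of the 3 values shown sit.

The compounds shown leave open whether the hydrogen, methoxy and chloro versions differ at all in this assay, and by how much.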